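The source may report more compounds than this note shows. Statements on the series, on what has been measured and on what is new or still open speak of the compounds shown alone.

Working notes on the series. In an assay for inhibition of serine/threonine-protein kinase Sgk1 (Homo sapiens), with stated times of 30 min and 60 min, in the presence of a further agent that is not named here (a higher number here means a weaker inhibitor, a lower number a stronger inhibitor), compound 1 `O=C(NC1CCN(C2CC2)C1)c1cc(-c2ccc(NS(=O)(=O)c3cccc(Cl)c3Cl)cc2)nc2[nH]ncc12` gives 610 nM. In this assay compound 3 `CC(C)NC(=O)c1cc(-c2ccc(NS(=O)(=O)c3cccc(Cl)c3Cl)cc2)nc2[nH]ncc12` gives 17600 nM. For compound 2 `CCNC(=O)c1cc(-c2ccc(NS(=O)(=O)c3cccc(Cl)c3Cl)cc2)nc2[nH]ncc12` this assay reports only a limit, < 1920 nM, and not a number; its place among the measured values is therefore set by the limit of < 1920 nM in this assay, at which 1 of the 3 values shown sits, alone. The measured steps are a 29-fold higher number from compound 1 to compound 3 (1.46 log units; beyond the scatter) and an at least 9.1-fold higher number from compound 2 to compound 3 (0.96 log units; beyond the scatter), while a step that the limit leaves unreadable from compound 1 to compound 2. Compound 4 `CCN1CCC(CNC(=O)c2cc(-c3ccc(NS(=O)(=O)c4cccc(Cl)c4Cl)cc3)nc3[nH]ncc23)C1` has not yet been measured in this assay. The change from compound 2 is 1-ethylpyrrolidin-3-yl in place of methyl on a saturated chain carbon bound to an amide-type nitrogen, which brings compound 4 close in kind to compound 1, carrying a pyrrolidine bearing a small alkyl on its nitrogen. The readable steps point the same way: compound 1 with its pyrrolidine is the lower value shown, and the isopropyl of compound 3 is the higher one. Compound 4 is therefore expected to give about 700 nM in this assay, within an estimated range of 200 nM to 2500 nM. For compound 4 the expected step is a step that the limit leaves unreadable from compound 2 to compound 4, noting that the limit on compound 2 leaves its exact size unreadable.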

Compound 4, half-maximal inhibitory concentration: 109 nM
For compound 4 the middle estimate is 6.4-fold (0.81 log units) above the measured one; measured number outside the range, below it.
By their numbers in this assay, from the lowest: compound 4; then compound 1; then compound 3.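

Putting (1-ethylpyrrolidin-3-yl)methyl in place of isopropyl on the amide-type nitrogen gives a 160-fold lower number from compound 3 to compound 4 (2.21 log units; beyond the scatter) in this assay, so this position accepts a much larger group than the small alkyl amides suggested. Set against the 1-cyclopropylpyrrolidin-3-yl group, the same substituent gives a 5.6-fold lower number from compound 1 to compound 4 (0.75 log units; beyond the scatter), which shows that the number in this series can still fall beyond that of compound 1. The step from compound 2 to compound 4 cannot be read, as compound 2 has only a limit and not a number: the limit of < 1920 nM in this assay, at which 1 of the 4 values shown sits.

The two pyrrolidine groups differ both in the methyl link and in ethyl against cyclopropyl on the ring nitrogen, and a (1-cyclopropylpyrrolidin-3-yl)methyl group would separate these two changes. From the compounds shown here alone, whether the ring nitrogen matters at all stays open, and a cyclopentylmethyl group on the amide-type nitrogen would test it.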